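Aryl amide variation on a bicyclic sulfonamide glycine transporter series

The compounds below may be only part of what the source reports. "The series", "measured", "known", "first", "only" and "open" are said of these compounds alone.

Compound 1 `Cn1cnc(S(=O)(=O)N2CC3CCC(NC(=O)c4ccccc4C(F)(F)F)C3C2)c1` carries a 2-(trifluoromethyl)phenyl amide on the shared core. For the measured compounds named here, in an assay on isolated protein for inhibition of sodium- and chloride-dependent glycine transporter 1 (Homo sapiens) (a higher number here means a weaker inhibitor, a lower number a stronger inhibitor), compound 1 gives 112000 nM, the only numerical value shown. Compound 2 `Cn1cnc(S(=O)(=O)N2CC3CCC(NC(=O)c4cccc(F)c4)C3C2)c1`, with a 3-fluorophenyl amide, reaches only the assay limit of > 10000000 nM, which is a limit of this assay and not a number (the limit of > 10000000 nM in this assay, at which 1 of the 2 values shown sits). The step of an at least 89-fold higher number from compound 1 to compound 2 (1.95 log units; beyond the scatter) is therefore large and in the direction of weaker inhibition.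

Compound 3 `Cn1cnc(S(=O)(=O)N2CC3CCC(NC(=O)c4ccc(Cl)c(Cl)c4)C3C2)c1` differs from compound 1 by 3,4-dichlorophenyl in place of 2-(trifluoromethyl)phenyl on a carbonyl carbon. The one measured step that bears on this change is the exchange of the same 2-(trifluoromethyl)phenyl group in compound 2, which cost at least the amount shown by an at least 89-fold higher number from compound 1 to compound 2 (1.95 log units; beyond the scatter). A step toward weaker inhibition is therefore expected for compound 3, though its size is uncertain, since a 3,4-dichlorophenyl group is not a 3-fluorophenyl group. The expected step is an 8.9-fold higher number from compound 1 to compound 3 (0.95 log units; beyond the scatter). Compound 3 is estimated at 1000000 nM in this assay, with a range from 150000 nM to 10000000 nM.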

Compound 3, half-maximal inhibitory concentration: 891000 nM
Estimate against measurement, compound 3: 1.1-fold (0.05 log units) above; measured number inside the range.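

In this assay, a replacement of 2-(trifluoromethyl)phenyl on this carbonyl carbon need not reach the assay limit, as 3,4-dichlorophenyl still gives a number, with an 8.0-fold higher number from compound 1 to compound 3 (0.90 log units; beyond the scatter). The two replacements are also not interchangeable, as the change from 3-fluorophenyl to 3,4-dichlorophenyl gives an at least 11-fold lower number from compound 2 to compound 3 (1.05 log units; beyond the scatter). The value of compound 2 is a limit of this assay and not a number: the limit of > 10000000 nM in this assay, at which 1 of the 3 values shown sits.

With only three aryl groups shown, the data do not separate the contribution of each substituent, and a 2-chlorophenyl or 4-chlorophenyl group would help to do so. Also open, as far as these compounds go, is how a non-aromatic group on this carbonyl carbon, such as cyclohexyl, or an aryl group carrying an amine or a carboxylic acid, would read.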